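Benzyl ether variation and cytotoxicity in the series

The compounds below may be only part of what the source reports. "The series", "measured", "known", "first", "only" and "open" are said of these compounds alone.

Compound 3 `O=c1c(O)c(-c2ccccc2)oc2cc(OCc3ccc(Br)cc3)cc(O)c12` in an ADME assay on Huh-5-2 cells (Homo sapiens) for cytotoxicity, read by WST assay, with a stated time of 3 days (on this read-out higher numbers stand for lower toxicity in this test and lower numbers for higher toxicity in this test), gives > 100000 nM, which is a limit of the assay and not a number (the limit of > 100000 nM in this assay, at which 1 of the 3 values shown sits). Compound 1 `N#Cc1ccccc1COc1cc(O)c2c(=O)c(O)c(-c3ccccc3)oc2c1` in this assay gives 22000 nM, and compound 2 `N#Cc1cccc(COc2cc(O)c3c(=O)c(O)c(-c4ccccc4)oc3c2)c1` in this assay gives 72000 nM. Among the measured steps, a 3.3-fold higher number from compound 1 to compound 2 (0.51 log units; beyond the scatter), an at least 4.5-fold higher number from compound 1 to compound 3 (0.65 log units; beyond the scatter), and an at least 1.3-fold higher number from compound 2 to compound 3 (0.14 log units; that floor lies within the scatter). All three compounds thus sit at weak cytotoxicity, with compound 3 at the limit.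

Compound 4 `COc1ccc(COc2cc(O)c3c(=O)c(O)c(-c4ccccc4)oc3c2)cc1` differs from compound 3 by methoxy in place of bromo on an aromatic carbon. Among the compounds with values here, none of the measured steps exchanges a bromo for a methoxy; each of them swaps one substituted phenyl for another on the saturated chain carbon bound to an oxygen on an aromatic ring, and the widest of them, an at least 4.5-fold higher number from compound 1 to compound 3 (0.65 log units; beyond the scatter), ends at the limit. Within the data shown here, no step gives a direction for the present change, so no movement beyond the scatter is expected in this assay, and the step from compound 3 to compound 4 is estimated as a number no higher from compound 3 to compound 4 (the limit leaves the size open). For compound 4 the expected value in this assay is 100000 nM, within 40000 nM to 250000 nM, with a fair chance that only a limit is again reported.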

Compound 4, half-maximal cytotoxic concentration: > 100000 nM
Compound 4 ended at the assay's limit; the forecaster's own chance of this, stated with the estimate: 55%; the middle value sits exactly at the limit.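

Compound 4 gives > 100000 nM in this assay, which is a limit of the assay and not a number, and it shares that limit with compound 3: the limit of > 100000 nM in this assay, at which 2 of the 4 values shown sit.

With both compounds at the limit, the exchange of bromo for methoxy cannot be read in size or direction, but the limit is now reached with two different groups at this place on the phenyl ring, so it does not depend on bromo alone. Against the two nitrile compounds, the series shows an at least 4.5-fold higher number from compound 1 to compound 4 (0.65 log units; beyond the scatter) and an at least 1.3-fold higher number from compound 2 to compound 4 (0.14 log units; that floor lies within the scatter), so compound 1 stays apart from both limit compounds beyond the scatter, while compound 2 is not separated from either of them.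

From the compounds shown here alone, whether the lower number of compound 1 belongs to the nitrile or to its place on the ring stays open, and a 4-cyanophenyl or 2-bromophenyl partner would separate the two. Also open, going by these compounds, is how an amine or a carboxylic acid on this phenyl ring would read in this assay, and whether any such group brings the number back below the limit.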